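The source may hold more compounds than are shown below. What is called first, only, known or untested is meant among the compounds shown, and "the series" means these compounds.

In a functional assay on HCT-116 cells (Homo sapiens) for cytotoxicity, read by MTT assay, with a stated time of 72 h; a higher number here means a weaker inhibitor, a lower number a stronger inhibitor:
Compound 1 `N[C@H]1CC[C@H](Nc2c(C(=O)NCc3ccc(F)cc3)nc(N3CCCCS3(=O)=O)c3cccnc23)CC1`: > 10000 nM, a limit.
Compound 2 `CS(=O)(=O)Oc1c(C(=O)NCc2ccc(F)cc2)nc(Br)c2cccnc12`: > 20000 nM, a limit.
Compound 3 `N[C@H]1CC[C@H](Nc2c(C(=O)NCc3ccc(F)cc3)nc(Br)c3cccnc23)CC1`: 7000 nM.

Within the data shown here, compound 3, at 7000 nM, holds the only actual number among the three. Compound 4 `N[C@H]1CC[C@H](Nc2c(C(=O)NCc3ccc(F)cc3)nc(N3CCCCC3)c3cccnc23)CC1` keeps the shared core and differs from it in one group: piperidin-1-yl in place of bromo on an aromatic carbon.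

The closest measured change is at this same carbon, where a six-membered non-aromatic ring gives way to bromine: an at least 1.4-fold lower number from compound 1 to compound 3 (0.15 log units; that floor lies within the scatter). The other measured change, an at least 2.8-fold lower number from compound 2 to compound 3 (0.45 log units; beyond the scatter), concerns the (4-aminocyclohexyl)amino group and bears on this question only weakly. On the evidence of compound 1, no step beyond the scatter is expected, with a slight lean towards a higher number in this assay. The expected change is a 1.1-fold higher number from compound 3 to compound 4 (0.06 log units; within the scatter). Compound 4 is estimated at 8000 nM, with an expected range of 2500 nM to 20000 nM.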

Compound 4, half-maximal inhibitory concentration: 8000 nM
Beside the measured number, compound 4's estimate shows no gap at the digits printed, within the range that was stated.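

At this aromatic carbon, para to a (4-aminocyclohexyl)amino group, the first pairing of bromo with a ring whose value is a real number shows piperidin-1-yl in place of bromo giving a 1.1-fold higher number from compound 3 to compound 4 (0.06 log units; within the scatter) in this assay. The swap from the group of 8 heavy atoms to piperidin-1-yl gives an at least 1.2-fold lower number from compound 1 to compound 4 (0.09 log units; that floor lies within the scatter). That step is only a floor, because the value of compound 1 is a limit: the limit of > 10000 nM in this assay, at which 1 of the 4 values shown sits.

The compounds shown leave open whether a morpholine ring, an open-chain amine or a carboxylic acid on this carbon would shift the number beyond the scatter.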